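A few compounds are considered here, and "the series" means these few. Any claim that something is new, unique, unknown or untested is made for them only; others in the source may bear on it.

Measured compounds:
Compound 1 `CCC1(CCCCN2CCN(c3cccc(Cl)c3)CC2)C(=O)Nc2ccccc21` — in an assay on membranes from frontal cortex for displacement of a labelled ligand from Adrenergic receptor alpha-1 (Rattus norvegicus), read by scintillation counting, with a stated time of 45 min (a higher number here means a weaker inhibitor, a lower number a stronger inhibitor), compound 1 gives 31 nM
Compound 2 `CCC1(CCCCN2CCN(c3cccc(Cl)c3)CC2)C(=O)Nc2cc(F)c(Cl)cc21` — in this assay compound 2 gives 117 nM

Compound 1 holds the lowest of the two numbers. Its nearest neighbour is compound 2, whose number stands higher by an amount that lies beyond the usual scatter of this assay, so compound 1 is the stronger binder of the pair. For the measured compounds named here, the two differ in the substitution of the shared core rather than in the aryl piperazine, and no single-point step between them is recorded.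

Compound 3 `CCC1(CCCCN2CCN(c3ccc(Cl)c(Cl)c3)CC2)C(=O)Nc2ccccc21` is not yet measured. It differs from compound 1 by chloro in place of hydrogen on an aromatic carbon, in words: chloro in place of hydrogen on an aromatic carbon, turning 3-chlorophenyl into 3,4-dichlorophenyl. Going by the values given here, no measured pair in this set shows this change, so the size of the step can only be guessed. A modest weakening, close to the edge of the scatter, is expected; the step from compound 1 to compound 3 is estimated as a 1.6-fold higher number from compound 1 to compound 3 (0.21 log units; within the scatter). Compound 3 is therefore expected to give about 50 nM, with a range from 15 nM to 160 nM.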

Compound 3, inhibition constant: 125 nM
Estimate against measurement, compound 3: 2.5-fold (0.40 log units) below; measured number inside the range.
By their numbers in this assay, from the lowest: compound 1; then compounds 2 and 3 (each within the scatter of the next).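

In this assay, the change from 3-chlorophenyl to 3,4-dichlorophenyl, chloro in place of hydrogen on an aromatic carbon ortho to the existing chloro group and para to a large group, gives a 4.0-fold higher number from compound 1 to compound 3 (0.61 log units; beyond the scatter). Compounds 1 and 2 share the same aryl piperazine and so said nothing about this ring; this step shows that the ring carbon is not indifferent to substitution, since a single added chlorine weakens binding by more than the usual scatter, though that rests on one pair of compounds and one entering group. Nothing available here accounts for the size or the direction of this step.

The compounds shown leave open whether a fluoro, methyl or methoxy group on the same carbon would bring a similar step, and whether the step would persist if the neighbouring chloro group were replaced by hydrogen or by fluoro. On these data alone, it also remains open how the added chloro group would read on the core of compound 2, which carries fluoro and chloro groups of its own.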